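The compounds below may be only part of what the source reports. "The series", "measured", "known", "first", "only" and "open" are said of these compounds alone.

Compound 2 `CCn1c(C(=O)NCCC(=O)OC)ccc1C(CC)(CC)c1ccc(OCS(=O)(=O)c2ccccc2)c(C)c1` carries a 2-(methoxycarbonyl)ethyl group on an amide-type nitrogen. In a functional assay on BXPC-3 cells (Homo sapiens) for antiproliferative activity, read by MTT assay, with a stated time of 24 h (on this read-out lower numbers stand for stronger inhibition and higher numbers for weaker inhibition), compound 2 reaches only a limit of the assay, > 50000 nM, not a number. Compound 1 `CCn1c(C(=O)N[C@H](C)C(=O)OC)ccc1C(CC)(CC)c1ccc(OCS(=O)(=O)c2ccccc2)c(C)c1` bears 1-(methoxycarbonyl)ethyl in the same place; in this assay compound 1 likewise reaches only a limit, > 50000 nM. Going by the values given here, the step that the two limits leave unreadable from compound 1 to compound 2 therefore cannot be sized, and the only guide is the limit of > 50000 nM in this assay, at which 2 of the 2 values shown sit. Compound 3 `CCn1c(C(=O)N[C@@H](CO)CCCO)ccc1C(CC)(CC)c1ccc(OCS(=O)(=O)c2ccccc2)c(C)c1` is not yet measured and differs from compound 2 in one place: a group of 7 heavy atoms (5 carbon, 2 oxygen; no ring) in place of a group of 6 heavy atoms (4 carbon, 2 oxygen; no ring), on an amide-type nitrogen. No measured step sizes such a change, and both measured values sit at the limit, so nothing points away from it. The step that the limit leaves unreadable from compound 2 to compound 3 is expected to leave compound 3 at or near the limit. Compound 3 is estimated at 60000 nM, with a range from 20000 nM to 200000 nM, and most likely the assay will again report only a limit.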

Compound 3, half-maximal inhibitory concentration: 16400 nM
Compound 3: middle estimate off by 3.7-fold (0.56 log units), on the high side; the measured number lies below the stated range.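

In this assay, the amide-type nitrogen proves to be a place where a change can be read: the group of compound 3, with its 2 hydrogen-bond donors, gives an at least 3.0-fold lower number from compound 2 to compound 3 (0.48 log units; beyond the scatter), and set against the other ester it gives an at least 3.0-fold lower number from compound 1 to compound 3 (0.48 log units; beyond the scatter). The step between the two esters cannot be read, so neither of them had shown that this position responds at all. Compound 3 is the only one of the three with a number, and the other two remain at a limit of the assay: the limit of > 50000 nM in this assay, at which 2 of the 3 values shown sit.

The compounds shown do not tell which feature of the entering group goes with the step, whether its hydroxyl groups, its chain length or its defined stereocentre. From the compounds shown here alone, it also remains open how a single hydroxyl, an amine or a carboxylic acid on the same nitrogen would compare.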